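A few compounds are considered here, and "the series" means these few. Any claim that something is new, unique, unknown or untested is made for them only; others in the source may bear on it.

Measured so far in a functional assay on Ramos cells (Homo sapiens) for antiproliferative activity; on this read-out higher numbers stand for weaker inhibition and lower numbers for stronger inhibition:

- Compound 1 `Nc1ncnc2c1c(-c1ccc(NC(=O)c3ccccc3)cc1)cn2[C@H]1CCN(C[C@@H]2CO2)C1` gives 2250 nM
- Compound 2 `Nc1ncnc2c1c(-c1ccc(Oc3ccccc3)cc1)cn2C[C@H]1CCCN1C(CO)CO` gives 15300 nM
- Compound 3 `Nc1ncnc2c1c(-c1cccc(-n3ncc4ccccc4c3=O)c1)cn2[C@H]1CCN(C[C@@H]2CO2)C1` gives 15200 nM

Compound 1 has the lowest number of the three, which makes it the strongest inhibitor here. Compound 2 and compound 3 both sit above it by more than the usual scatter.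

Compound 4 `CC(C)(C)c1ccc(Oc2ccc(-c3cn([C@H]4CCN(C[C@@H]5CO5)C4)c4ncnc(N)c34)cc2)cc1` is still unmeasured. It differs from compound 1 in one place, with 4-(tert-butyl)phenoxy in place of benzamido on an aromatic carbon, para to a large group 4-(tert-butyl)phenoxy in place of benzamido on an aromatic carbon in the count of what changes. Going by the values given here, no measured pair isolates this swap, so the guidance is indirect. The closest hint is compound 2, which also carries a phenoxy group and gives 15300 nM but differs from compound 1 elsewhere too. The estimated step of a 2.7-fold higher number from compound 1 to compound 4 (0.43 log units; beyond the scatter) in this assay is therefore a moderate one, toward a higher number and weaker inhibition. The uncertainty is wide, and compound 4 is estimated at 6000 nM with an expected range from 1800 nM to 20000 nM in this read-out.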

Compound 4, half-maximal inhibitory concentration: 11200 nM
Beside the measured number, compound 4's estimate is 1.9-fold (0.27 log units) below it; the range from low to high includes it.
By their numbers in this assay, from the lowest: compound 1; then compounds 4, 3 and 2 (each within the scatter of the next).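

In this assay, going by these compounds alone, the pair of compound 1 and compound 4 gives the first direct reading of this place, on an aromatic carbon para to a large group, and the change from benzamido to 4-(tert-butyl)phenoxy costs activity, with a 5.0-fold higher number from compound 1 to compound 4 (0.70 log units; beyond the scatter) as the step. Both groups carry one six-membered aromatic ring of carbon only, so this place does not treat every group with such a ring alike. The benzamido group has a hydrogen-bond donor and a double bond outside aromatic rings while the entering group has neither, but this single pair cannot show which difference matters, and no measurement here explains the loss. As far as these compounds go, what remains open is whether a urea or a sulfonamide at this place, which would keep a hydrogen-bond donor, would hold the value of compound 1. Also open, from the compounds shown here alone, is how an unsubstituted phenoxy group would behave on the core of compound 1, which would separate the effect of the tert-butyl group from that of the ether link.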